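Notes on the series: side chain change at the amide-bearing carbon

The source may hold more compounds than are shown below. What is called first, only, known or untested is meant among the compounds shown, and "the series" means these compounds.

Measured so far:
compound 1 `N=C(N)NCCC[C@H](NC(=O)CN(c1nc(Cl)nc2[nH]cnc12)C1CC1)C(=O)O` — 17%
compound 2 `N=C(N)NCCC[C@H](NC(=O)CN(c1nc(Cl)nc2[nH]cnc12)C1CC1)C(=O)OCc1ccccc1` — 10.2%

In a functional assay on the whole organism (Tail, strain ICR) with Mus musculus as the target, in the tail flick test, with a stated time of 120 min, at a dose of 25 umol/kg by the oral route (on this read-out higher numbers stand for a stronger effect at the one dose given and lower numbers for a weaker effect), compound 1 gives 17%, and compound 2 gives 10.2%; the step of a number 6.8 percentage points lower from compound 1 to compound 2 (within the scatter) lies within the scatter, so the two numbers are not told apart and compound 1 does not stand apart from compound 2.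

Compound 3 `O=C(O)C[C@H](NC(=O)CN(c1nc(Cl)nc2[nH]cnc12)C1CC1)C(=O)O` differs from compound 1 by a group of 3 heavy atoms (1 carbon, 2 oxygen; no ring) in place of a group of 6 heavy atoms (3 carbon, 3 nitrogen; no ring), on a saturated chain carbon, two bonds along the chain from an amide-type nitrogen and a carbonyl carbon. Among the compounds with values here, the one measured step concerns the oxygen next to the carbonyl group, not this chain carbon, so it does not bear on the change; no measured pair touches the group that leaves or the carboxy that enters. The expectation therefore rests on the change itself and is uncertain. A step to a weaker read-out is estimated, a number 9 percentage points lower from compound 1 to compound 3 (within the scatter), though it could fall within the scatter. For compound 3 the estimate is 8%, in the range 0% to 22%.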

Compound 3, a percentage reported as activity, at one dose (the size of the read-out at that dose, not a potency): 22%
The estimate for compound 3 lay 14 percentage points below the measured number; the range from low to high includes it.
By their numbers in this assay, from the lowest: compounds 2, 1 and 3 (each within the scatter of the next, the first and the last beyond it).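

Within the data shown here, this is the first look at the saturated chain carbon itself, as the earlier pair spoke only to the oxygen bearing benzyl. In this assay, carboxy in place of the group of 6 heavy atoms (3 carbon, 3 nitrogen; no ring) gives a number 5 percentage points higher from compound 1 to compound 3 (within the scatter), so the read-out does not tell these two side chains apart at this dose. The 3 nitrogen atoms of the leaving group are thus not needed to keep the read-out in the range of compound 1. Nothing at hand accounts for this result.

From the compounds shown here alone, whether a simple amine, a methyl or a longer chain ending in a carboxylic acid on this chain carbon would move the read-out beyond the scatter remains open. Also open, going by these compounds, is how benzyl, as carried by compound 2, would read on compound 3.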